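A few compounds are considered here, and "the series" means these few. Any claim that something is new, unique, unknown or untested is made for them only; others in the source may bear on it.

Measured so far: compound 1 `CN(C)C(=O)c1ccncc1Nc1cc(-c2ccc3ccn(C)c3c2)c2nccnc2c1` gives 499 nM in an assay for inhibition of 6-phosphofructo-2-kinase/fructose-2,6-bisphosphatase 3 (Homo sapiens), read by ADP-Glo, with a stated time of 2 h; a lower number here means a stronger inhibitor, a higher number a weaker inhibitor; compound 2 `CC(=O)N1CCC(NC(=O)c2ccncc2Nc2cc(-c3ccc4ccn(C)c4c3)c3nccnc3c2)CC1` gives 18 nM; compound 3 `Cn1ccc2ccc(-c3cc(Nc4cnccc4C(=O)NCC4COCCN4)cc4nccnc34)cc21` gives 33 nM.

Compound 3 stands second highest of the three numbers, close to compound 2 and far from compound 1. Compound 4 `CN1CCC(CNC(=O)c2ccncc2Nc2cc(-c3ccc4ccn(C)c4c3)c3nccnc3c2)C1` differs from compound 3 by 1-methylpyrrolidin-3-yl in place of morpholin-3-yl on a saturated chain carbon bound to an amide-type nitrogen. Within the data shown here, the steps that bear on this are those changing the group on the amide-type nitrogen: a 28-fold lower number from compound 1 to compound 2 (1.44 log units; beyond the scatter) and a 15-fold lower number from compound 1 to compound 3 (1.18 log units; beyond the scatter) were large, whereas a 1.8-fold higher number from compound 2 to compound 3 (0.26 log units; within the scatter), a swap between two ring-bearing groups like this one, was small. A step of similar size is therefore expected here, in no clear direction, with a 1.1-fold lower number from compound 3 to compound 4 (0.04 log units; within the scatter). Compound 4 is estimated at 30 nM, expected between 10 nM and 90 nM.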

Compound 4, half-maximal inhibitory concentration: 74 nM
Compound 4: the middle estimate sits 2.5-fold (0.39 log units) below what was measured, and the stated range covers the measured number.
By their numbers in this assay, from the lowest: compounds 2 and 3 (each within the scatter of the next); then compound 4; then compound 1.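

In this assay, a swap between two ring-bearing groups on this amide-type nitrogen can matter: 1-methylpyrrolidin-3-yl in place of morpholin-3-yl gives a step beyond the scatter (a 2.2-fold higher number from compound 3 to compound 4 (0.35 log units; beyond the scatter)), and the gap to the acetylpiperidine amide is wider (a 4.1-fold higher number from compound 2 to compound 4 (0.61 log units; beyond the scatter)). Even so, the gain over the dimethylamino amide partly remains (a 6.7-fold lower number from compound 1 to compound 4 (0.83 log units; beyond the scatter)). No measurement here accounts for these steps.

Ring size, the ring oxygen and the methyl on the ring nitrogen all change together in this swap, so their separate shares stay open. A pyrrolidin-3-yl without the methyl, or a 1-methylpiperidin-3-yl, on the same chain carbon would begin to separate them.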